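Amino for Chloro on a Purine Core: Expected Cytotoxicity

The source may hold more compounds than are shown below. What is called first, only, known or untested is meant among the compounds shown, and "the series" means these compounds.

Three compounds have been measured in a functional assay on NCI/ADR-RES cells (Homo sapiens) for cytotoxicity, read by sulforhodamine B assay, with a stated time of 48 h; a higher number here means a weaker inhibitor of growth, a lower number a stronger inhibitor of growth:

compound 1, `Nc1nc(Cl)c2ncn(Cc3ccc(CCl)cc3)c2n1`, compound 1 gives 3310 nM
compound 2, `ClCc1cccc(Cn2cnc3c(Cl)nc(Cl)nc32)c1`, compound 2 gives 2390 nM
compound 3, `ClCc1ccc(Cn2cnc3c(Cl)nc(Cl)nc32)cc1`, compound 3 gives 16600 nM

Compounds 2 and 3 are built from the same atoms joined differently; the difference between their cores is not broken down here. Compound 2 and compound 1 lie within the scatter of each other, while compound 3 gives the highest number of the three.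

Compound 1 arises from compound 3 by one change, (amino in place of chloro on an aromatic carbon). That change brought a 5.0-fold lower number from compound 3 to compound 1 (0.70 log units; beyond the scatter).

Compound 4, `Nc1nc(Cl)c2ncn(Cc3cccc(CCl)c3)c2n1`, has not yet been measured. It arises from compound 2 by amino in place of chloro on an aromatic carbon, and the place of this change reads word for word as for the step from compound 3 to compound 1, so it is the same change made on the core of compound 2 instead of the core of compound 3.

The expectation for compound 4 rests on a single earlier instance, and the cores of compound 2 and compound 3 differ in a way that is not broken down, so the step is taken only as a guide. Beside a 5.0-fold lower number from compound 3 to compound 1 (0.70 log units; beyond the scatter), compound 4 is expected to show a 3.0-fold lower number from compound 2 to compound 4 (0.48 log units; beyond the scatter), because compound 2 already gives 2390 nM and the same change lowered the number from compound 3 to compound 1. For compound 4 the estimated value in this assay is 800 nM, with a likely range from 300 nM to 2500 nM.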

Compound 4, concentration for 50% growth inhibition: 4890 nM
Compound 4: middle estimate off by 6.1-fold (0.79 log units), on the low side; the measured number lies above the stated range.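

In this assay, amino in place of chloro on an aromatic carbon did not repeat its earlier direction when made on a second core, where it brought a 2.0-fold higher number from compound 2 to compound 4 (0.31 log units; beyond the scatter). Set side by side, the two instances of this one change differ in direction as well as in size: the same change on two cores in this assay, a 5.0-fold lower number (0.70 log units; beyond the scatter) from compound 3 to compound 1 and a 2.0-fold higher number (0.31 log units; beyond the scatter) from compound 2 to compound 4, 10-fold (1.01 log units) apart, beyond the scatter of two such steps This shows that, within these four compounds, the result of the change depends on the core that carries it, so the step from one core cannot be carried over to the other as a fixed shift or even as a reliable direction. It does not show why the two cores respond differently or which instance is more typical, and two pairs are too few to establish a rule for the wider series.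

The compounds shown leave open what feature of the two cores separates these opposite outcomes, as the difference between them is not broken down here. They also leave open whether a methylamino or hydroxyl group, placed between the two ring nitrogen atoms in place of the amino group, would split the two cores in the same way.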